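From 2-methylphenyl to 4-fluorophenyl: an expected modest gain

The compounds below may be only part of what the source reports. "The series", "measured", "known", "first", "only" and "open" are said of these compounds alone.

Compound 1 `COc1ccc(N2CCN(C(=S)SCc3ccc4nc(N)nc(N)c4c3)CC2)cc1` in a functional assay on HCT-116 cells (Homo sapiens) for antiproliferative activity, read by MTT assay, with a stated time of 72 h; a lower number here means a stronger inhibitor, a higher number a weaker inhibitor: 2270 nM
Compound 2 `Cc1ccc(N2CCN(C(=S)SCc3ccc4nc(N)nc(N)c4c3)CC2)cc1`: 5510 nM
Compound 3 `Cc1ccccc1N1CCN(C(=S)SCc2ccc3nc(N)nc(N)c3c2)CC1`: 11800 nM

Compound 3 at 11800 nM has the highest number of the three and is the weakest inhibitor among them in this assay. Compound 4 `Nc1nc(N)c2cc(CSC(=S)N3CCN(c4ccc(F)cc4)CC3)ccc2n1` carries 4-fluorophenyl in place of 2-methylphenyl on an amine nitrogen in a ring and keeps the shared core. Among the compounds with values here, no measured compound carries 4-fluorophenyl, so the guidance is indirect. Two modest measured steps bear on the change: a 2.1-fold higher number from compound 2 to compound 3 (0.33 log units; beyond the scatter), with 2-methylphenyl replacing 4-methylphenyl, and a 5.2-fold higher number from compound 1 to compound 3 (0.72 log units; beyond the scatter), with 2-methylphenyl replacing 4-methoxyphenyl. Read in reverse, they suggest a modest move to a lower number. The expected change is a 2.6-fold lower number from compound 3 to compound 4 (0.42 log units; beyond the scatter). Compound 4 is estimated at 4500 nM, with an expected range of 1800 nM to 11000 nM.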

Compound 4, half-maximal inhibitory concentration: 3270 nM
For compound 4 the middle estimate is 1.4-fold (0.14 log units) above the measured one; the measured number falls inside the stated range.
By their numbers in this assay, from the lowest: compounds 1, 4 and 2 (each within the scatter of the next, the first and the last beyond it); then compound 3.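

In this assay, 4-fluorophenyl gives a 3.6-fold lower number from compound 3 to compound 4 (0.56 log units; beyond the scatter), so compound 3, with 2-methylphenyl, now stands apart from the 4-methoxyphenyl, 4-methylphenyl and 4-fluorophenyl compounds. Fluoro in place of methyl gives a 1.7-fold lower number from compound 2 to compound 4 (0.23 log units; within the scatter), and fluoro in place of methoxy gives a 1.4-fold higher number from compound 1 to compound 4 (0.16 log units; within the scatter), so neither step separates fluoro from the group it replaces. Nothing available explains these differences. The compounds shown leave open whether 2-fluorophenyl would give a number close to that of compound 3 or of compound 4. From the compounds shown here alone, how unsubstituted phenyl or 4-chlorophenyl would compare also remains open.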